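A Chloro-Fluoro Swap Repeated on a Weaker Core

The compounds below may be only part of what the source reports. "The series", "measured", "known", "first", "only" and "open" are said of these compounds alone.

Compound 1 `O=C(CN1CCN(c2nnc(Cc3ccncc3)c3ccccc23)CC1)Nc1cccc(F)c1` and compound 2 `O=C(CN1CCN(c2nnc(Cc3ccncc3)c3ccccc23)CC1)Nc1ccc(F)c(Cl)c1` share one core and differ only on the amide-type nitrogen: 3-chloro-4-fluorophenyl in place of 3-fluorophenyl on an amide-type nitrogen. In a functional assay on MDA-MB-231 cells (Homo sapiens) for cytotoxicity, read by MTT assay, with a stated time of 72 h (a lower number here means a stronger inhibitor, a higher number a weaker inhibitor), compound 1 gives 4.4 nM, and compound 2 gives 4 nM; the step of a 1.1-fold lower number from compound 1 to compound 2 (0.04 log units; within the scatter) lies within the scatter of repeated measurements. Compound 3 `O=C(CN1CCN(c2nnc(Cc3ccccc3)c3ccccc23)CC1)Nc1cccc(F)c1` keeps the 3-fluorophenyl of compound 1 but has a different core: phenyl in place of pyridin-4-yl on a saturated chain carbon bound to an aromatic carbon. In this assay compound 3 gives 3730 nM, a far weaker inhibitor, as the step of an 850-fold higher number from compound 1 to compound 3 (2.93 log units; beyond the scatter) shows.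

Compound 4 `O=C(CN1CCN(c2nnc(Cc3ccccc3)c3ccccc23)CC1)Nc1ccc(F)c(Cl)c1` is compound 3 with the change already seen between compound 1 and compound 2: 3-chloro-4-fluorophenyl in place of 3-fluorophenyl on an amide-type nitrogen. The place is the same in both pairs, so this is the same change, now made on the weaker core. For compound 4 a small step, a 1.1-fold lower number from compound 3 to compound 4 (0.03 log units; within the scatter), is expected because the earlier step of a 1.1-fold lower number from compound 1 to compound 2 (0.04 log units; within the scatter) lay within the scatter. The estimate for compound 4 in this assay is therefore 3500 nM, with a likely range from 1500 nM to 8000 nM.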

Compound 4, half-maximal inhibitory concentration: 7360 nM
For compound 4 the middle estimate is 2.1-fold (0.32 log units) below the measured one; measured number inside the range.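

On the weaker core, the swap to 3-chloro-4-fluorophenyl again gives a small step in this assay, a 2.0-fold higher number from compound 3 to compound 4 (0.30 log units; within the scatter), and the two cores agree on this change: the same change on two cores in this assay, a 1.1-fold lower number (0.04 log units; within the scatter) from compound 1 to compound 2 and a 2.0-fold higher number (0.30 log units; within the scatter) from compound 3 to compound 4, 2.2-fold (0.34 log units) apart, within the scatter of two such steps. The reverse view holds as well, since phenyl in place of pyridin-4-yl gives a 1800-fold higher number from compound 2 to compound 4 (3.26 log units; beyond the scatter) with 3-chloro-4-fluorophenyl on the amide-type nitrogen, a large step much like the one seen with 3-fluorophenyl: the same change on two cores in this assay, an 850-fold higher number (2.93 log units; beyond the scatter) from compound 1 to compound 3 and a 1800-fold higher number (3.26 log units; beyond the scatter) from compound 2 to compound 4, 2.2-fold (0.34 log units) apart, within the scatter of two such steps. For these four compounds, each change carries from one partner to the other with about the same size, but two pairs per change are a thin base, and they do not show why pyridin-4-yl counts for so much or whether other groups would carry over as well.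

From the compounds shown here alone, it remains open whether pyridin-3-yl or pyridin-2-yl in place of pyridin-4-yl would match the strength of compound 1. Also open, going by these compounds, is whether a methoxyphenyl or a longer chain on the amide-type nitrogen would behave alike on both cores.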